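Notes on the amide switch and a tert-butyl analogue

The source may report more compounds than this note shows. Statements on the series, on what has been measured and on what is new or still open speak of the compounds shown alone.

Measured so far:
compound 1, `COc1cc(N(Cc2nc3ccccc3[nH]2)S(=O)(=O)c2ccc(Br)cc2)cc(OC)c1OC`, 7740 nM
compound 2, `COc1cc(N(Cc2nc3ccccc3[nH]2)C(=O)c2ccccc2)cc(OC)c1OC`, > 50000 nM (a limit)

Compound 1 in a functional assay on MCF7 cells (Homo sapiens) for inhibition, read by MTT assay, with a stated time of 48 h (on this read-out lower numbers stand for stronger inhibition and higher numbers for weaker inhibition), gives 7740 nM. Compound 2 in this assay gives only a limit, > 50000 nM. The step of an at least 6.4-fold higher number from compound 1 to compound 2 (0.81 log units; beyond the scatter) is therefore only a bound, set by the limit of > 50000 nM in this assay, at which 1 of the 2 values shown sits. Compound 3 `COc1cc(N(Cc2nc3ccccc3[nH]2)C(=O)c2ccc(C(C)(C)C)cc2)cc(OC)c1OC` differs from compound 2 by tert-butyl in place of hydrogen on an aromatic carbon. Among the measured compounds shown here, no measured step touches this position, and compound 2 itself stands at the limit, so nothing sets a direction. Compound 3 is expected near 50000 nM, range 15000 nM to 150000 nM. The expected step is a number no higher from compound 2 to compound 3 (the limit leaves the size open), most likely again reported only as a limit.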

Compound 3, half-maximal inhibitory concentration: 48800 nM
Beside the measured number, compound 3's estimate is 1.0-fold (0.01 log units) above it, within the range that was stated.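

In this assay, compound 3 gives the only measured number among the amides shown, 48800 nM, so tert-butyl at this aromatic carbon moves the amide series onto a readable value. Compound 2 gives only a limit, > 50000 nM. Going from phenyl to 4-(tert-butyl)phenyl reads as an at least 1.0-fold lower number from compound 2 to compound 3 (0.01 log units; that floor lies within the scatter), and its true size stays open because one end of the step is not a number: the limit of > 50000 nM in this assay, at which 1 of the 3 values shown sits.

Going by these compounds, whether an amine or a carboxylic acid on this same carbon would give a number different from that of compound 3 stays open. So does the effect of a shorter chain such as methyl there.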